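Swapping Isopropyl for 2-Methoxyethyl on an Amide Nitrogen

The source may hold more compounds than are shown below. What is called first, only, known or untested is meant among the compounds shown, and "the series" means these compounds.

Three related compounds have been tested in a physicochemical assay for solubility (a lower number here means a less soluble compound, a higher number a more soluble compound), and none of them has returned an exact number. Compound 1 (`CNC(=O)c1cc(C(=O)NC2CC2)cn([C@H](C)c2ccccc2)c1=O`) gives >= 168 ug/mL as a limit of the assay, not a number. Compound 2 (`CNC(=O)c1cc(C(=O)NC(C)C)cn(Cc2ccccc2)c1=O`) gives >= 136 ug/mL as a limit too. Compound 3 (`CNC(=O)c1ccc(=O)n(Cc2ccccc2)c1`) gives >= 108 ug/mL as a limit as well. Compound 2 therefore stands among three limits, and they cannot be put in any order.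

Compound 4 (`CNC(=O)c1cc(C(=O)NCCOC)cn(Cc2ccccc2)c1=O`) has not been measured yet. It carries 2-methoxyethyl in place of isopropyl on an amide-type nitrogen and is otherwise the same as compound 2. Among the compounds with values here, no measured pair shows a single change like this one, so the expectation rests only on those limits. The expected step (a step that the limit leaves unreadable from compound 2 to compound 4) stays within the usual scatter of this assay and has no clear direction. Compound 4 is estimated at 150 ug/mL with a range of 80 ug/mL to 260 ug/mL and may well return only a limit.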

Compound 4, solubility: >= 164 ug/mL
Compound 4 gave a limit, no number; the forecaster's own chance of this, stated with the estimate: 70%; at least 1.0-fold (0.03 log units) between middle value and limit.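

Compound 2 and compound 4 both returned only limits, not exact numbers, so the step between them cannot be read. The compounds shown leave open how 2-methoxyethyl and isopropyl on the amide-type nitrogen truly compare in this assay.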